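Shortening the sulfanyl chain on the shared core

The compounds below may be only part of what the source reports. "The series", "measured", "known", "first", "only" and "open" are said of these compounds alone.

Compound 3 has the structure `CCCCCSc1nc(N)c2nc(O)n(Cc3ccccc3)c2n1`. In a functional assay on the whole organism for activation, with Mus musculus as the target (on this read-out higher numbers stand for an effect only at larger amounts of compound and lower numbers for an effect already at smaller amounts), compound 3 gives 1 mg/kg, the lowest of the two numbers shown. Compound 2, `CCCc1nc(N)c2nc(O)n(Cc3ccccc3)c2n1`, gives 3 mg/kg in this assay. Compound 1, `Nc1nc(SCc2ccccc2)nc2c1nc(O)n2Cc1ccccc1`, gives > 1 mg/kg in this assay, which is a limit and not a number. The step of a 3.0-fold lower number from compound 2 to compound 3 (0.48 log units; beyond the scatter) is a modest one beyond the scatter; the step of a number no higher from compound 1 to compound 3 (the limit leaves the size open) is not readable in size because of the limit (the limit of > 1 mg/kg in this assay, at which 1 of the 3 values shown sits).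

Compound 4, `CSc1nc(N)c2nc(O)n(Cc3ccccc3)c2n1`, is not yet measured. It differs from compound 3 as follows: hydrogen in place of butyl on a saturated chain carbon bound to a sulfur. The step from compound 2 to compound 3, which lengthened the chain on the aromatic carbon, lowered the number; the present step cuts that chain back to methylsulfanyl, shorter than propyl in compound 2. Within the data shown here, the one measured step with a readable size points toward a higher number on shortening, so a step back toward compound 2 is expected. Compound 4 is expected to give about 3 mg/kg, within 1 mg/kg to 10 mg/kg, which means an estimated step of a 3.0-fold higher number from compound 3 to compound 4 (0.48 log units; beyond the scatter).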

Compound 4, minimum effective dose: 0.1 mg/kg
Beside the measured number, compound 4's estimate is 30-fold (1.48 log units) above it, and the stated range ends above it.
By their numbers in this assay, from the lowest: compound 4; then compound 3; then compound 2.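

Cutting pentylsulfanyl back to methylsulfanyl gives a 10-fold lower number from compound 3 to compound 4 (1.00 log units; beyond the scatter) in this assay, so a long chain on the sulfur is not needed for a low number here. Methylsulfanyl in place of propyl gives a 30-fold lower number from compound 2 to compound 4 (1.48 log units; beyond the scatter), a larger step than a 3.0-fold lower number from compound 2 to compound 3 (0.48 log units; beyond the scatter) with pentylsulfanyl, so the earlier gain from the longer chain does not extend to the sulfanyl chains as a rule that longer is better. Compound 1 carries a limit and not a number, so an at least 10-fold lower number from compound 1 to compound 4 (1.00 log units; beyond the scatter) gives only a bound on the change from benzylsulfanyl: the limit of > 1 mg/kg in this assay, at which 1 of the 4 values shown sits.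

The compounds shown leave open how much of the step from propyl belongs to the sulfur and how much to chain length, which a propylsulfanyl group on the same aromatic carbon would separate. Also open, as far as these compounds go, is whether an ethylsulfanyl chain, or a carboxylic acid at the end of the chain, keeps the low number.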